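Methyl to cyclopropylmethyl on the core of compound 1

The compounds below may be only part of what the source reports. "The series", "measured", "known", "first", "only" and "open" are said of these compounds alone.

Measured compounds:
Compound 1 `COc1ccc(-n2c(C)nc3c(NC(C4CC4)C4CC4)nc(C)nc32)cc1` gives 19 nM in a functional assay on CHO cells for antagonist activity at corticotropin-releasing factor receptor 1 (Homo sapiens), read by cAMP accumulation; a lower number here means a stronger inhibitor, a higher number a weaker inhibitor.
Compound 2 `COc1ccc(-n2c(C)nc3c(NC(C4CC4)C4CC4)nc(C)nc32)c(C)c1` gives 14 nM.

Going by the values given here, compound 1 gives the higher of the two numbers; the only measured step, a 1.4-fold lower number from compound 1 to compound 2 (0.13 log units; within the scatter), lies within the scatter and concerns a different position, so it does not bear on the change at hand. Compound 3 `COc1ccc(-n2c(CC3CC3)nc3c(NC(C4CC4)C4CC4)nc(C)nc32)cc1` differs from compound 1 by cyclopropyl in place of hydrogen on a saturated chain carbon bound to an aromatic carbon. Among the compounds with values here, no measured step touches this position, so no shift beyond the scatter is expected in this assay, in either direction. Compound 3 is therefore estimated at 25 nM, with a range of 8 nM to 80 nM. The expected step is a 1.3-fold higher number from compound 1 to compound 3 (0.12 log units; within the scatter).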

Compound 3, inhibition constant: 308 nM
Compound 3: the middle estimate sits 12-fold (1.09 log units) below what was measured; measured number above the stated range.
By their numbers in this assay, from the lowest: compounds 2 and 1 (each within the scatter of the next); then compound 3.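

In this assay, this saturated chain carbon bound to an aromatic carbon proves sensitive to substitution: methyl to cyclopropylmethyl gives a 16-fold higher number from compound 1 to compound 3 (1.21 log units; beyond the scatter). Going by these compounds alone, the earlier step, at a different position, stayed within the scatter, so this is the first change to move the number clearly. Nothing measured here accounts for the step.

Open, from the compounds shown here alone, is whether an ethyl group, a longer chain or an amine at this place would stay close to compound 1 or fall nearer compound 3. Also open, going by these compounds, is whether the same change would give a similar step on compound 2.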